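Fused aza-aromatic aryl series: cytotoxicity on gastric cells

The compounds below may be only part of what the source reports. "The series", "measured", "known", "first", "only" and "open" are said of these compounds alone.

Compound 1 `Cc1nc2c3ccccc3ccc2c2nc3c(ccc4ccccc43)c(-c3ccccc3Cl)c12`: 52500 nM in a functional assay on AGS cells (Homo sapiens) for cytotoxicity, read by MTT assay, with a stated time of 48 h; on this read-out higher numbers stand for weaker inhibition and lower numbers for stronger inhibition
Compound 2 `Cc1ccc(-c2c3ccc4ccccc4c3nc3c2c(C)nc2c4ccccc4ccc32)cc1`: > 80000 nM
Compound 3 `Cc1nc2c3ccccc3ccc2c2nc3c(ccc4ccccc43)c(-c3cc([N+](=O)[O-])ccc3N)c12`: 17800 nM

The value of compound 2 is a limit of the assay, not a number; compound 2 sits at the limit of > 80000 nM in this assay, at which 1 of the 3 values shown sits. Its distance from compound 1 stays within the scatter, while compound 3 lies clearly lower. Compound 4 `Cc1nc2c3ccccc3ccc2c2nc3c(ccc4ccccc43)c(-c3cc(O)nc4ccccc34)c12` differs from compound 2 by 2-hydroxyquinolin-4-yl in place of 4-methylphenyl on an aromatic carbon. Among the compounds with values here, two measured steps bear on this position: an at least 1.5-fold higher number from compound 1 to compound 2 (0.18 log units; that floor lies within the scatter), and an at least 4.4-fold lower number from compound 2 to compound 3 (0.65 log units; beyond the scatter). Within the data shown here, the one step that replaced 4-methylphenyl by another substituted aryl group went down, so a decrease in this assay of about an at least 3.2-fold lower number from compound 2 to compound 4 (0.50 log units; beyond the scatter) is expected for compound 4, resting on an at least 4.4-fold lower number from compound 2 to compound 3 (0.65 log units; beyond the scatter). Compound 4 is therefore estimated at 25000 nM, within 8000 nM to 80000 nM.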

Compound 4, half-maximal inhibitory concentration: 15800 nM
Compound 4: the middle estimate sits 1.6-fold (0.20 log units) above what was measured; the measured number falls inside the stated range.
By their numbers in this assay, from the lowest: compounds 4 and 3 (each within the scatter of the next); then compound 1. At a limit, above all of these: compound 2.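

Within the data shown here, the position opposite the ring nitrogen accepts 2-hydroxyquinolin-4-yl, the first group here with two aromatic rings and a ring hetero atom, and in this assay the numbers still fall: an at least 5.0-fold lower number from compound 2 to compound 4 (0.70 log units; beyond the scatter), and a 3.3-fold lower number from compound 1 to compound 4 (0.52 log units; beyond the scatter). Against 2-amino-5-nitrophenyl nothing separates it, a 1.1-fold lower number from compound 3 to compound 4 (0.05 log units; within the scatter), so two quite different groups give matching results. Compound 2 stands at a limit: the limit of > 80000 nM in this assay, at which 1 of the 4 values shown sits.

Open, as far as these compounds go, is whether the hydroxyl or the quinoline ring carries the change. Also open, from the compounds shown here alone, is how a simple aminophenyl or a phenyl carboxylic acid would behave at this position.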